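Replacing 4-butylphenyl with butyl on a triple bond

The compounds below may be only part of what the source reports. "The series", "measured", "known", "first", "only" and "open" are said of these compounds alone.

Compound 1 `CCCCCCC#Cc1cn(C/C=C/CN2C(=O)c3ccccc3C2=O)c(=O)[nH]c1=O` (34000 nM)
Compound 2 `CCCCCc1ccc(C#Cc2cn(C/C=C/CN3C(=O)c4ccccc4C3=O)c(=O)[nH]c2=O)cc1` (27000 nM)
Compound 3 `CCCCc1ccc(C#Cc2cn(C/C=C/CN3C(=O)c4ccccc4C3=O)c(=O)[nH]c2=O)cc1` (94000 nM)

Of the three compounds measured in a functional assay on HeLa cells (Homo sapiens) for antiproliferative activity, read by MTT assay, with a stated time of 3 days (on this read-out higher numbers stand for weaker inhibition and lower numbers for stronger inhibition), compound 3 has the highest number (94000 nM) and is the weakest inhibitor. Compound 4 `CCCCC#Cc1cn(C/C=C/CN2C(=O)c3ccccc3C2=O)c(=O)[nH]c1=O` has not yet been measured. It carries butyl in place of 4-butylphenyl on a triple-bonded carbon.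

Among the measured compounds shown here, two measured steps bear on this change. With 4-butylphenyl in place of hexyl, compound 3 lies modestly above compound 1, as a 2.8-fold higher number from compound 1 to compound 3 (0.44 log units; beyond the scatter) shows, so losing the ring might bring the number down again. Compound 2 and compound 3 differ in chain length, and a 3.5-fold higher number from compound 2 to compound 3 (0.54 log units; beyond the scatter) links the shorter chain to the higher number in this single pair. Butyl is also shorter than the hexyl of compound 1, so compound 4 need not return to the level of compound 1. These two indications pull in opposite directions, and only a small fall is expected, with a 1.3-fold lower number from compound 3 to compound 4 (0.13 log units; within the scatter) as the estimated step, within the scatter. Compound 4 is estimated at 70000 nM, with 28000 nM to 180000 nM as the expected range.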

Compound 4, half-maximal inhibitory concentration: 89000 nM
For compound 4 the middle estimate is 1.3-fold (0.10 log units) below the measured one, and the stated range covers the measured number.
By their numbers in this assay, from the lowest: compounds 2 and 1 (each within the scatter of the next); then compounds 4 and 3 (each within the scatter of the next).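

In this assay the step from the aryl to the plain chain on the triple-bonded carbon gives no readable difference (a 1.1-fold lower number from compound 3 to compound 4 (0.02 log units; within the scatter)), so with a butyl chain present, the six-membered aromatic ring of 4-butylphenyl can be removed without a change beyond the scatter. Chain length, by contrast, does register at this place: shortening hexyl to butyl, with no ring in either compound, gives a modest rise (a 2.6-fold higher number from compound 1 to compound 4 (0.42 log units; beyond the scatter)), and the number also stands modestly higher when butyl replaces 4-pentylphenyl (a 3.3-fold higher number from compound 2 to compound 4 (0.52 log units; beyond the scatter)). Together with the earlier pair that differs by a single methyl on the chain (a 3.5-fold higher number from compound 2 to compound 3 (0.54 log units; beyond the scatter)), the shorter chain now goes with the higher number both with and without the ring, and none of these four compounds goes against that pattern.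

Still open, going by these compounds, is whether a chain longer than hexyl on the triple-bonded carbon would bring the number lower, or whether a chain ending in an amine or a carboxylic acid would fit the same pattern. Nothing given here explains why the chain length shifts these numbers while the ring does not.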